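This account rests on a few compounds, and the source may have more. Where it says the series, first, only, none or still open, it means among the compounds named here.

Measured in an ADME assay on microsomes from liver (Homo sapiens) for metabolic stability; a lower number here means that the compound disappears faster, a higher number that the compound lasts longer:
- compound 1 `CC(C)C(Cc1ncc[nH]1)c1ccc(-c2ccc3cccc(F)c3c2)[nH]c1=O`: 0.106 h
- compound 2 `CC(C)C(c1ncco1)c1ccc(-c2ccc3cccc(F)c3c2)[nH]c1=O`: 0.178 h
- compound 3 `CC(C)C(c1nnc[nH]1)c1ccc(-c2ccc3cccc(F)c3c2)[nH]c1=O`: 0.905 h

Compound 3 lasts longest of the three, and both gaps lie beyond the scatter: an 8.5-fold higher number from compound 1 to compound 3 (0.93 log units; beyond the scatter) and a 5.1-fold higher number from compound 2 to compound 3 (0.71 log units; beyond the scatter). By contrast, a 1.7-fold higher number from compound 1 to compound 2 (0.23 log units; within the scatter) stays within the scatter. Compound 4 `CC(C)C(c1noc(=O)[nH]1)c1ccc(-c2ccc3cccc(F)c3c2)[nH]c1=O` differs from compound 3 on a saturated chain carbon bound to an aromatic carbon and a saturated chain carbon: a group of 6 heavy atoms (2 carbon, 2 nitrogen, 2 oxygen; one five-membered aromatic ring with 3 hetero atoms) in place of a group of 5 heavy atoms (2 carbon, 3 nitrogen; one five-membered aromatic ring with 3 hetero atoms), on a saturated chain carbon bound to an aromatic carbon and a saturated chain carbon. These steps show that changes at this place can matter, but none tests the entering group, so no direction can be favoured. The new group is again a five-membered aromatic ring. The expected result is a 1.1-fold higher number from compound 3 to compound 4 (0.04 log units; within the scatter), with no clear change anticipated. For compound 4 the estimate is 1 h, with an expected range from 0.3 h to 3 h.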

Compound 4, half-life: > 3 h
Compound 4: no number, only a limit (the forecaster's own chance of this, stated with the estimate: 5%); at least 3.0-fold (0.47 log units) between middle value and limit.
By their numbers in this assay, from the lowest: compounds 1 and 2 (each within the scatter of the next); then compound 3. At a limit, above all of these: compound 4.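

In this assay, compound 4 gives a limit of the assay rather than a number: the limit of > 3 h in this assay, at which 1 of the 4 values shown sits. This shows that the 4H-1,2,4-triazol-3-yl ring of compound 3 was not the ceiling at this saturated chain carbon, since swapping it gives an at least 3.3-fold higher number from compound 3 to compound 4 (0.52 log units; beyond the scatter). The wider comparisons give an at least 16-fold higher number from compound 2 to compound 4 (1.22 log units; beyond the scatter) and an at least 28-fold higher number from compound 1 to compound 4 (1.45 log units; beyond the scatter), so the ring held here can shift this read-out by a large margin.

Going by these compounds, the true size of all three steps stays open, as does whether a carboxylic acid at this place would last as long.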